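The compounds below may be only part of what the source reports. "The series", "measured", "known", "first", "only" and "open" are said of these compounds alone.

Three compounds share one core and differ only in the aryl group on the oxygen on a saturated carbon. Compound 1, `Cc1ccc(OC[C@@H]2[C@H]3CC[C@H](c4nc(C(=O)O)cs4)O[C@H]3C[C@H]2O)cc1`, carries a 4-methylphenyl there and gives 27 nM in a functional assay on CHO cells for agonist activity at prostaglandin E2 receptor EP2 subtype (Homo sapiens), read by HTRF and cAMP accumulation, with a stated time of 30 min; a lower number here means that less compound is needed, a higher number that more compound is needed for the effect. Compound 2, `O=C(O)c1csc([C@H]2CC[C@@H]3[C@@H](COc4cccc(F)c4)[C@H](O)C[C@@H]3O2)n1`, carries a 3-fluorophenyl and gives 5.4 nM in this assay. Compound 3, `Cc1cccc(OC[C@@H]2[C@H]3CC[C@H](c4nc(C(=O)O)cs4)O[C@H]3C[C@H]2O)c1`, carries a 3-methylphenyl and gives 3.6 nM in this assay. Compound 3 thus sits at the low end of the three numbers: the step of a 7.5-fold lower number from compound 1 to compound 3 (0.88 log units; beyond the scatter) is beyond the scatter, whereas a 1.5-fold lower number from compound 2 to compound 3 (0.18 log units; within the scatter) is within it, so compounds 2 and 3 cannot be told apart.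

Compound 4, `O=C(O)c1csc([C@H]2CC[C@@H]3[C@@H](COc4ccccc4Cl)[C@H](O)C[C@@H]3O2)n1`, brings the change (2-chlorophenyl in place of 3-methylphenyl on an oxygen on a saturated carbon). Among the measured compounds shown here, no measured step places a substituent at that position or brings in a chlorine, so there is no direct precedent. For the measured compounds named here, the steps that bear on it indirectly are a 5.0-fold lower number from compound 1 to compound 2 (0.70 log units; beyond the scatter) and a 7.5-fold lower number from compound 1 to compound 3 (0.88 log units; beyond the scatter), each showing that moving the substituent around the ring shifts the number by a modest amount, and a 1.5-fold lower number from compound 2 to compound 3 (0.18 log units; within the scatter), showing that exchanging fluoro for methyl at one position changes little. Since compound 3 already holds the low end, the change is expected to give a number somewhat higher than that of compound 3, a step of a 2.8-fold higher number from compound 3 to compound 4 (0.44 log units; beyond the scatter). Compound 4 is therefore estimated at 10 nM in this assay, with a range from 3 nM to 40 nM.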

Compound 4, half-maximal effective concentration: 3.3 nM
Beside the measured number, compound 4's estimate is 3.0-fold (0.48 log units) above it; the range from low to high includes it.
By their numbers in this assay, from the lowest: compounds 4, 3 and 2 (each within the scatter of the next); then compound 1.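

The 2-chlorophenyl on an oxygen on a saturated carbon holds the low end in this assay: the exchange stays within the scatter whether it replaces 3-methylphenyl (a 1.1-fold lower number from compound 3 to compound 4 (0.04 log units; within the scatter)) or 3-fluorophenyl (a 1.6-fold lower number from compound 2 to compound 4 (0.21 log units; within the scatter)). Only the 4-methylphenyl stands apart (an 8.2-fold lower number from compound 1 to compound 4 (0.91 log units; beyond the scatter), beyond the scatter), so this position now carries a chlorine as well as a fluoro or a methyl, on a different ring position, without the number leaving the low group formed by compound 2, compound 3 and compound 4. Nothing measured here accounts for why these three aryl groups cannot be told apart or why the 4-methylphenyl differs from them.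

The compounds shown leave open whether the low numbers need a substituent at all, a question that plain phenyl would address, and they tie the chlorine and its ring position together, which 2-methylphenyl and 3-chlorophenyl would pull apart. They also leave open whether the higher number of compound 1 belongs to the methyl or to its ring position, which 4-chlorophenyl or 4-fluorophenyl would test, and how methoxy or trifluoromethyl would read at this position.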